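Replacing the fused aromatic group of compound 2

The compounds below may be only part of what the source reports. "The series", "measured", "known", "first", "only" and "open" are said of these compounds alone.

In a functional assay on KB 3-1 cells (Homo sapiens), with a stated time of 72 h (a higher number here means a weaker inhibitor, a lower number a stronger inhibitor), compound 1 `Cc1nc2cc([C@@H]3C[C@@H]4O[C@]4(C)CCC[C@H](C)[C@H](O)[C@@H](C)C(=O)C(C)(C)[C@@H](O)CC(=O)O3)ccc2s1` gives 0.13 nM and compound 2 `Cc1nc2cc([C@@H]3C[C@@H]4O[C@]4(C)CCC[C@H](C)[C@H](O)[C@@H](C)C(=O)C(C)(C)[C@@H](O)CC(=O)O3)ccc2n1C` gives 0.14 nM so the two stand level within the scatter. Compound 3 `C/C(=C\c1ccccn1)[C@@H]1C[C@@H]2O[C@]2(C)CCC[C@H](C)[C@H](O)[C@@H](C)C(=O)C(C)(C)[C@@H](O)CC(=O)O1` keeps the shared core, and the whole difference is a group of 9 heavy atoms (8 carbon, 1 nitrogen; one six-membered aromatic ring with 1 hetero atom) in place of a group of 11 heavy atoms (9 carbon, 2 nitrogen; one five-membered aromatic ring with 2 hetero atoms, one six-membered aromatic ring of carbon only), on a saturated ring carbon and it sits next to the ring oxygen. The entering group also carries 1 double bond outside aromatic rings. Within the data shown here, only one measured step bears on this, a 1.1-fold higher number from compound 1 to compound 2 (0.03 log units; within the scatter) where one fused group takes the place of another. Both of those groups hold a five-membered aromatic ring and a six-membered aromatic ring, while compound 3 has a single ring there, so that step is only a weak guide. A modest weakening is therefore expected, with a 2.1-fold higher number from compound 2 to compound 3 (0.33 log units; beyond the scatter) as the estimated step toward a higher number in this assay on this evidence. For compound 3 the expected value is 0.3 nM within an estimated range of 0.1 nM to 1.2 nM on this measure.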

Compound 3, half-maximal inhibitory concentration: 0.3 nM
The estimate for compound 3 equals the measured number at the digits printed, and the stated range covers the measured number.
By their numbers in this assay, from the lowest: compounds 1 and 2 (each within the scatter of the next); then compound 3.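

Until now, the two fused groups on this saturated ring carbon, next to the ring oxygen, stood level, so nothing showed whether the position responds to its group at all. Among these compounds, compound 3 gives the first change beyond the scatter: in this assay there is a 2.1-fold higher number from compound 2 to compound 3 (0.33 log units; beyond the scatter) and a 2.3-fold higher number from compound 1 to compound 3 (0.36 log units; beyond the scatter). Both steps are modest, so a single six-membered aromatic ring with 1 hetero atom, carried on a double bond, can take the place of either fused group at a small cost, though nothing given here explains the shift.

The double bond and the single ring arrive together, and the compounds shown do not separate what each contributes. Also open, as far as these compounds go, is how an amine or a carboxylic acid on that ring, or a longer chain in place of the double bond, would read in this assay.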